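The source may report more compounds than this note shows. Statements on the series, on what has been measured and on what is new or still open speak of the compounds shown alone.

Measured in an ADME assay on MDCK cells (Canis lupus familiaris) for permeability, read by LC-MS, with a stated time of 90 min, tested at 2 uM; a higher number here means that the compound crosses the layer faster, a lower number that the compound crosses the layer more slowly:
- compound 1 `Cc1cc(C)c(CN2CCc3c(Cl)cc([C@H](CO)[C@H]4CCOC4)c(Cl)c3C2=O)c(=O)[nH]1`: 2.9 10^-6 cm/s
- compound 2 `Cc1cc(C)c(CN2CCc3c(Cl)cc(-c4c(C)noc4C)c(Cl)c3C2=O)c(=O)[nH]1`: 15.7 10^-6 cm/s

Of these two, compound 2 stands higher, at 15.7 10^-6 cm/s. The next compound is compound 3 `Cc1cc(C)c(CN2CCc3c(Cl)cc([C@@H](CO)[C@H]4CCCO4)c(Cl)c3C2=O)c(=O)[nH]1`, and the change is a group of 8 heavy atoms (6 carbon, 2 oxygen; one five-membered non-aromatic ring with 1 hetero atom) in place of a group of 7 heavy atoms (5 carbon, 1 nitrogen, 1 oxygen; one five-membered aromatic ring with 2 hetero atoms), on an aromatic carbon. The 3,5-dimethyl-1,2-oxazol-4-yl group leaves, and a group with a five-membered non-aromatic ring with 1 hetero atom enters in its place.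

Within the data shown here, only one measured step bears on this: a 5.4-fold higher number from compound 1 to compound 2 (0.73 log units; beyond the scatter). That step went the opposite way, from a group of the same counted make-up to the 3,5-dimethyl-1,2-oxazol-4-yl group. The two entering groups are not identical, and one step is thin evidence. Even so, a fall of similar size, beyond the scatter, is expected here. The expected step in this assay is a 4.5-fold lower number from compound 2 to compound 3 (0.65 log units; beyond the scatter). For compound 3 the estimated value is 3.5 10^-6 cm/s, with an expected range of 1.5 10^-6 cm/s to 8 10^-6 cm/s.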

Compound 3, apparent permeability: 8.5 10^-6 cm/s
Compound 3: middle estimate off by 2.4-fold (0.39 log units), on the low side, and the stated range ends below it.
By their numbers in this assay, from the lowest: compound 1; then compounds 3 and 2 (each within the scatter of the next).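

Swapping the 3,5-dimethyl-1,2-oxazol-4-yl group for the non-aromatic ring group of compound 3 gives a 1.8-fold lower number from compound 2 to compound 3 (0.27 log units; within the scatter) in this assay, so at this aromatic carbon a group with a hydrogen-bond donor and two defined stereocentres can read level with the oxazole. The groups of compound 1 and compound 3 match in every count, yet the step is a 2.9-fold higher number from compound 1 to compound 3 (0.47 log units; beyond the scatter) and lies beyond the scatter, so the counted make-up alone does not fix the number at this position. Nothing measured here explains why these two closely matched groups differ.

The compounds shown do not separate the effect of ring arrangement from that of stereochemistry, since compound 1 and compound 3 differ in both. They also leave open how an amine or a carboxylic acid at this aromatic carbon would read.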